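A few compounds are considered here, and "the series" means these few. Any claim that something is new, unique, unknown or untested is made for them only; others in the source may bear on it.

Compound 2 `OCCC(NC1CCN(CCCc2c[nH]c3ccc(-n4cnnc4)cc23)CC1)c1ccccc1`: 5.1 nM
Compound 1 `c1ccc2c(c1)CCC2NC1CCN(CCCc2c[nH]c3ccc(-n4cnnc4)cc23)CC1`: 25 nM

In an assay on CHO cells for agonist activity at 5-hydroxytryptamine receptor 1D (Homo sapiens), read by GTPgammaS binding (on this read-out lower numbers stand for an effect already at smaller amounts and higher numbers for an effect only at larger amounts of compound), compound 2 gives 5.1 nM, the lower of the two numbers, while compound 1 gives 25 nM. Within the data shown here, the one measured step, a 4.9-fold lower number from compound 1 to compound 2 (0.69 log units; beyond the scatter), came with a swap of the group on the amine nitrogen. Compound 3 `C[C@H](NC1CCN(CCCc2c[nH]c3ccc(-n4cnnc4)cc23)CC1)c1ccccc1` differs from compound 2 by 1-phenylethyl in place of 3-hydroxy-1-phenylpropyl on an amine nitrogen. The group that leaves carries the hydroxy and the entering group carries none; compound 1, which also has no hydrogen-bond donor in this position, sits at 25 nM. Compound 3 is therefore expected to show a 2.4-fold higher number from compound 2 to compound 3 (0.37 log units; beyond the scatter), landing near 12 nM, within 4 nM to 35 nM.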

Compound 3, half-maximal effective concentration: 12 nM
Compound 3: the middle estimate sits on the measured number at the digits printed; the range from low to high includes it.
By their numbers in this assay, from the lowest: compound 2; then compound 3; then compound 1.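

Replacing 3-hydroxy-1-phenylpropyl with 1-phenylethyl on the amine nitrogen gives a 2.4-fold higher number from compound 2 to compound 3 (0.37 log units; beyond the scatter) and so leaves the group with the hydroxy holding the lowest number of the three. Among the two groups without a hydroxy, 1-phenylethyl in place of 2,3-dihydro-1H-inden-1-yl gives a 2.1-fold lower number from compound 1 to compound 3 (0.32 log units; beyond the scatter) and shows that the number at this position also shifts when no hydroxy is involved. No measurement here explains either step.

On these data alone, it remains open whether the hydroxy or the longer chain accounts for the gap between compound 2 and compound 3. A plain 1-phenylpropyl group, or an amine in place of the hydroxy, would help separate the two.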